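The compounds below may be only part of what the source reports. "The series", "measured", "known", "first", "only" and "open" are said of these compounds alone.

Compound 1 `Cc1ccc(S(=O)(=O)NCc2cn(C[C@H](O)[C@H]3OC(=O)C(OCc4ccccc4)=C3OCc3ccccc3)nn2)cc1` gives 50 nM in an ADME assay on HFF cells (Homo sapiens) for cytotoxicity, read by MTT assay, with a stated time of 72 h; a lower number here means a stronger inhibitor, a higher number a weaker inhibitor. Compound 2 `O=C1O[C@H]([C@@H](O)Cn2cc(-c3cc(F)cc(F)c3)nn2)C(OCc2ccccc2)=C1OCc1ccccc1` shows only a limit in this assay, > 100000 nM, which is the limit of > 100000 nM in this assay, at which 1 of the 2 values shown sits.

Compound 1 thus holds the only number shown; the other value is a limit. Compound 3 `O=C1O[C@H]([C@@H](O)Cn2cc(CNS(=O)(=O)c3ccc(Cl)cc3F)nn2)C(OCc2ccccc2)=C1OCc1ccccc1` differs from compound 1 by 4-chloro-2-fluorophenyl in place of 4-methylphenyl on a sulfonyl sulfur. For the measured compounds named here, the single measured step, an at least 2000-fold higher number from compound 1 to compound 2 (3.30 log units; beyond the scatter), swaps the whole (((4-methylphenyl)sulfonyl)amino)methyl group and so does not bear on a change confined to the aryl on the sulfonyl sulfur. Going by the values given here, with no guidance from measured steps, no shift beyond the scatter is expected in this assay. Compound 3 is estimated at 70 nM, between 20 nM and 300 nM. That estimate means a step of a 1.4-fold higher number from compound 1 to compound 3 (0.15 log units; within the scatter).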

Compound 3, half-maximal inhibitory concentration: 20 nM
For compound 3 the middle estimate is 3.5-fold (0.54 log units) above the measured one; the range from low to high includes it.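

In this assay, the aryl on the sulfonyl sulfur proves able to move the number on its own: 4-chloro-2-fluorophenyl in place of 4-methylphenyl gives a 2.5-fold lower number from compound 1 to compound 3 (0.40 log units; beyond the scatter). The earlier step replaced the whole (((4-methylphenyl)sulfonyl)amino)methyl group, whereas this change leaves the sulfonamide nitrogen and the shared core untouched. Nothing measured here accounts for the shift.

The compounds shown leave open whether the chlorine or the fluorine carries this step. They also leave open how an amine or a simple alkyl chain on the sulfonyl sulfur would read in this assay.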